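Triazolylalkyl phenyl series: cytotoxicity notes on the enantiomer step

A few compounds are considered here, and "the series" means these few. Any claim that something is new, unique, unknown or untested is made for them only; others in the source may bear on it.

Measured so far:
compound 1 `CC[C@@H](CCn1cncn1)c1ccccc1` — 91.2 ug/mL
compound 2 `CCCC[C@H](CCn1cncn1)c1ccccc1` — 48.3 ug/mL

In an ADME assay on RD cells (Homo sapiens) for cytotoxicity, read by MTT assay, with a stated time of 3 days (a higher number here means that more compound is tolerated, a lower number that less compound is tolerated), compound 1 gives 91.2 ug/mL and compound 2 gives 48.3 ug/mL. Going by the values given here, compound 2 holds the lower of the two numbers, but its only neighbour, compound 1, lies within the scatter of it, so no order between these two can be read, and nothing beyond the pair itself is supported.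

Compound 3 `CCCC[C@@H](CCn1cncn1)c1ccccc1` has not yet been measured in this assay. Relative to compound 2 the change is the two compounds have the same atoms and bonds and differ only in configuration as drawn: 1 of 1 stereo elements differ; a stereocentre at a saturated chain carbon is drawn R in compound 2 and S in compound 3. Among the compounds with values here, no step between measured compounds exists in this set, so there is no precedent for a configuration change at this stereocentre.

With identical atoms and bonds, a change in configuration alone gives no basis for expecting movement in this assay, and the step of a 1.0-fold higher number from compound 2 to compound 3 (0.02 log units; within the scatter) is expected to be none beyond the scatter. Compound 3 is therefore estimated at 50 ug/mL in this assay, with a range from 25 ug/mL to 100 ug/mL, taking the value of compound 2 as the anchor.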

Compound 3, half-maximal cytotoxic concentration: 47.5 ug/mL
Compound 3: the middle estimate sits 1.1-fold (0.02 log units) above what was measured; measured number inside the range.
By their numbers in this assay, from the lowest: compounds 3, 2 and 1 (each within the scatter of the next).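

In this assay this stereocentre now has a step of its own, and a 1.0-fold lower number from compound 2 to compound 3 (0.01 log units; within the scatter) shows that drawing the saturated chain carbon R or S gives no readable difference in this pair. The ethyl in place of hydrogen on a saturated chain carbon, three bonds along the chain from an aromatic carbon, also gains a step, and a 1.9-fold lower number from compound 1 to compound 3 (0.28 log units; within the scatter) gives no order between those two compounds either. The comparison of compound 2 with compound 3 therefore tests configuration alone, and that reading rests on a single structural fact: the fact that compounds 2 and 3 differ only in the configuration as drawn.

Neither result shows whether the configuration at this carbon would stay without consequence in this assay with a longer chain there, or with an amine or a carboxylic acid at the end of that chain. The compounds shown also leave open whether any change at this position can move the number beyond the scatter, as every step so far lies within it.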